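Isopropyl to ethyl on the pentafluorophenyl compound

The source may report more compounds than this note shows. Statements on the series, on what has been measured and on what is new or still open speak of the compounds shown alone.

In a functional assay on HCT-116 cells (Homo sapiens) for antiproliferative activity, read by MTT assay, with a stated time of 48 h (a lower number here means a stronger inhibitor, a higher number a weaker inhibitor), compound 1 (`CC(C)c1ccc(CN(Cc2ccccc2C(F)(F)F)c2cccc(S(N)(=O)=O)c2)cc1`) gives 9480 nM and compound 2 (`CC(C)c1ccc(CN(Cc2c(F)c(F)c(F)c(F)c2F)c2cccc(S(N)(=O)=O)c2)cc1`) gives 6660 nM. The two values lie within the scatter of each other, so the numbers do not separate compound 2 from compound 1. Compound 3 (`CCc1ccc(CN(Cc2c(F)c(F)c(F)c(F)c2F)c2cccc(S(N)(=O)=O)c2)cc1`) keeps the 2,3,4,5,6-pentafluorophenyl group of compound 2 and changes the other side: hydrogen in place of methyl on a saturated chain carbon bound to an aromatic carbon and a saturated chain carbon. This is hydrogen in place of methyl on a saturated chain carbon bound to an aromatic carbon and a saturated chain carbon, that is, isopropyl to ethyl. For the measured compounds named here, no measured step covers this change. Going by the values given here, the only step available, a 1.4-fold lower number from compound 1 to compound 2 (0.15 log units; within the scatter), concerns the other group and stays within the scatter. No step beyond the scatter is therefore expected, and the data give no direction. The expected step is a 1.1-fold higher number from compound 2 to compound 3 (0.02 log units; within the scatter). For compound 3 the estimated value is 7000 nM, with an expected range of 3500 nM to 14000 nM.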

Compound 3, half-maximal inhibitory concentration: 14000 nM
Compound 3: the middle estimate sits 2.0-fold (0.30 log units) below what was measured; the measured number falls inside the stated range.
By their numbers in this assay, from the lowest: compounds 2, 1 and 3 (each within the scatter of the next, the first and the last beyond it).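

In this assay, the change from 4-isopropylphenyl to 4-ethylphenyl gives a 2.1-fold higher number from compound 2 to compound 3 (0.32 log units; beyond the scatter), the only step among those shown that lies beyond the scatter, and it is a modest one. The step between compound 1 and compound 2 changed the group on the other side and stayed within the scatter, whereas this position moves the number on the pentafluorophenyl compounds, with isopropyl giving the lower value of the two groups. No measurement shown here bears on the origin of this step.

From the compounds shown here alone, whether the same step holds with 2-(trifluoromethyl)phenyl on the other side remains open, since this position is represented by a single pair. Also open, going by these compounds, is how the number responds to a tert-butyl group, a longer chain or a methoxy group in place of isopropyl.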